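An Ester Swapped for an Ether on the Chain

A few compounds are considered here, and "the series" means these few. Any claim that something is new, unique, unknown or untested is made for them only; others in the source may bear on it.

Compound 1, `COCCn1cc(C(=O)C(=O)Nc2ccc(C(F)(F)F)nc2)c2ccccc21`: > 10000 nM
Compound 2, `COC(=O)CCn1cc(C(=O)C(=O)Nc2ccc(OC)nc2)c2ccccc21`: 168 nM

In a functional assay on FaDu cells (Homo sapiens) for cytotoxicity, read by MTT assay, with a stated time of 72 h (a higher number here means that more compound is tolerated, a lower number that less compound is tolerated), compound 1 returns only a limit of the assay, > 10000 nM, which is the limit of > 10000 nM in this assay, at which 1 of the 2 values shown sits. For the measured compounds named here, compound 2 gives 168 nM in this assay and so holds the only actual number among the two values shown. Compound 3, `COc1ccc(NC(=O)C(=O)c2cn(CCOC(C)C)c3ccccc23)cn1`, has not yet been measured. It differs from compound 2 in one place: isopropoxy in place of methoxycarbonyl on a saturated chain carbon, two bonds along the chain from an aromatic nitrogen. Going by the values given here, no measured pair carries this change, so no step can be read from the data; a small shift, not clearly beyond the scatter, is expected. For compound 3 the expected step is a 1.8-fold higher number from compound 2 to compound 3 (0.25 log units; within the scatter). Compound 3 is estimated at 300 nM in this assay, within 80 nM to 1500 nM.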

Compound 3, concentration lethal to 50% of the cells: 211 nM
For compound 3 the middle estimate is 1.4-fold (0.15 log units) above the measured one; measured number inside the range.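

Going from the ester to the ether on this chain gives a 1.3-fold higher number from compound 2 to compound 3 (0.10 log units; within the scatter) in this assay, so the methoxycarbonyl group is not required at this position for a value of this size. Nothing shown gives a cause for this result.

As far as these compounds go, whether a carboxylic acid, an amine or a longer chain would be tolerated at this position stays open. Compound 1 carries a limit and differs from compound 3 in more than one place, so no step can be read from it.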